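Replacing a Chlorophenyl Hydrazide by a Dimethylphenyl One

This account rests on a few compounds, and the source may have more. Where it says the series, first, only, none or still open, it means among the compounds named here.

Of the compounds shown here, three have so far been measured in an assay on cells for agonist activity at ecdysone receptor (Bombyx mori), read by a luciferase reporter, with a stated time of 24 h; on this read-out lower numbers stand for an effect already at smaller amounts and higher numbers for an effect only at larger amounts of compound. Compound 1 `CC(C)(C)N(NC(=O)c1ccccc1)C(=O)c1ccccc1C(F)(F)F` gives 631 nM, compound 2 `Cc1ccccc1C(=O)N(NC(=O)c1ccccc1)C(C)(C)C` gives 224 nM, and compound 3 `CC(C)(C)N(NC(=O)c1cccc(Cl)c1)C(=O)c1ccccc1Cl` gives 155 nM. Compound 3 has the lowest number of the three: its gap to compound 2 is within the scatter, while its gap to compound 1 lies beyond it. Going by the values given here, the only one-place step between measured compounds is a 2.8-fold lower number from compound 1 to compound 2 (0.45 log units; beyond the scatter), a modest step that concerns a different part of the shared core than the change now considered.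

Compound 4 `Cc1ccc(C(=O)NN(C(=O)c2ccccc2Cl)C(C)(C)C)c(C)c1` differs from compound 3 by 2,4-dimethylphenyl in place of 3-chlorophenyl on a carbonyl carbon. Among the compounds with values here, no measured pair varies this group, so the data give no direct guide for the size or direction of the step; the one measured step, which lies elsewhere in the core, only shows that a single aryl change can move the number by a modest amount. Compound 4 is therefore expected to give about 200 nM, with a range from 60 nM to 700 nM. The estimate means a step of a 1.3-fold higher number from compound 3 to compound 4 (0.11 log units; within the scatter), which is expected to stay within the scatter.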

Compound 4, half-maximal effective concentration: 162 nM
Compound 4: middle estimate off by 1.2-fold (0.09 log units), on the high side; measured number inside the range.
By their numbers in this assay, from the lowest: compounds 3, 4 and 2 (each within the scatter of the next); then compound 1.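

Going by these compounds alone, compounds 3 and 4 give the first direct reading at this position, the aryl group on a carbonyl carbon whose other neighbour is an amide-type nitrogen: in this assay the exchange of 3-chlorophenyl for 2,4-dimethylphenyl is a 1.0-fold higher number from compound 3 to compound 4 (0.02 log units; within the scatter) and so leaves the two compounds indistinguishable. The read-out therefore does not separate these two aryl groups, although the chlorine of the leaving group is gone and the entering group consists of carbon alone. No measurement is available that would explain this match.

A single pair cannot show whether this position tolerates change in general, nor what the 2,4-dimethylphenyl result owes to each of its methyl groups, since the two are varied only together and the 3-chlorophenyl group is compared with this one replacement alone. Going by these compounds, it also remains open how the number would respond if the aromatic ring here gave way to an amine, a carboxylic acid or a longer alkyl chain on the same carbonyl carbon.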